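A dimethoxyphenyl amine in place of a chlorobenzyl group

The compounds below may be only part of what the source reports. "The series", "measured", "known", "first", "only" and "open" are said of these compounds alone.

Compound 1, `CC(C)CCn1cnc2c(NCc3cccc(Cl)c3)nc(N[C@H]3CC[C@H](N)CC3)nc21`, gives 6600 nM in a functional assay on BT-474 cells (Homo sapiens) for inhibition, read by fluorescence, with a stated time of 72 h; on this read-out higher numbers stand for weaker inhibition of growth and lower numbers for stronger inhibition of growth.
Compound 2, `CC(C)=CCC/C(C)=C/Cn1cnc2c(Nc3cccc(Cl)c3)nc(N[C@H]3CC[C@H](N)CC3)nc21`, gives 4300 nM in this assay.
Compound 3, `N[C@H]1CC[C@H](Nc2nc(Nc3ccc(O)cc3)c3ncn(C4CCCCC4)c3n2)CC1`, gives 27300 nM in this assay.

Among these three numbers, compound 1 holds the second highest. Compound 2 is nearest to it, and the gap between the two lies within the usual scatter of repeated measurements, so the data do not tell them apart. Compound 3 is furthest away, with a higher number that lies beyond the scatter, so compound 3 inhibits growth of these cells less strongly than compound 1 does.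

Compound 4, `COc1cc(Nc2nc(N[C@H]3CC[C@H](N)CC3)nc3c2ncn3CCC(C)C)cc(OC)c1`, has not yet been measured. It differs from compound 1 in one place: 3,5-dimethoxyphenyl in place of 3-chlorobenzyl on a nitrogen on an aromatic ring. For the measured compounds named here, no pair of measured compounds isolates this change. Compound 2 and compound 3 each carry an aromatic ring directly on the corresponding nitrogen, as compound 4 does, but both differ from compound 1 in other places as well, and their two values stand on either side of compound 1.

On this basis the step of a 1.2-fold lower number from compound 1 to compound 4 (0.08 log units; within the scatter) is expected to be small, with no clear direction beyond the scatter. Compound 4 is therefore estimated to give about 5500 nM, with a likely range from 1500 nM to 20000 nM.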

Compound 4, concentration for 50% growth inhibition: 5900 nM
Compound 4: the middle estimate sits 1.1-fold (0.03 log units) below what was measured; the measured number falls inside the stated range.
By their numbers in this assay, from the lowest: compounds 2, 4 and 1 (each within the scatter of the next); then compound 3.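

In this assay, the change from (3-chlorobenzyl)amino to (3,5-dimethoxyphenyl)amino gives a 1.1-fold lower number from compound 1 to compound 4 (0.05 log units; within the scatter), so the data do not tell these two compounds apart. Unlike compound 2 and compound 3, which differ from compound 1 in other places as well, compound 4 isolates this position, with the rest of compound 1 held fixed. On this one comparison, the nitrogen on the aromatic ring takes a group with hydrogen-bond acceptors that 3-chlorobenzyl lacks, and with a different link to its ring, without a step beyond the scatter. Nothing shown here explains why the step is this small.

For the compounds shown here, the single step changes the ring substituents and the link to the nitrogen together, so it remains open how a 3,5-dimethoxybenzyl or a 3-chlorophenyl group would compare on this nitrogen, with everything else as in compound 1. Going by these compounds, it is also open whether this tolerance extends to groups of another kind, such as a carboxylic acid or an amine on the aromatic ring.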